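Replacing Butyl with Methylcarbamoyl on a Hydrazone Aryl Ring

This account rests on a few compounds, and the source may have more. Where it says the series, first, only, none or still open, it means among the compounds named here.

Compound 1, `CC1CC/C(=N\Nc2ccc(Br)cc2)c2ncc(C(=O)O)c(=O)n21`, gives 0.8 umol/kg in a functional assay on the whole organism for inhibition, with Rattus norvegicus as the target; a lower number here means that less compound is needed, a higher number that more compound is needed for the effect.
Compound 2, `COc1ccc(N/N=C2\CCC(C)n3c2ncc(C(=O)O)c3=O)cc1`, gives 0.8 umol/kg.
Compound 3, `CCCCc1ccc(N/N=C2\CCC(C)n3c2ncc(C(=O)O)c3=O)cc1`, gives 7.8 umol/kg.

Compound 3 stands highest of the three numbers, and its separation from both neighbours is beyond the scatter: a 9.8-fold higher number from compound 1 to compound 3 (0.99 log units; beyond the scatter) and a 9.8-fold higher number from compound 2 to compound 3 (0.99 log units; beyond the scatter). Between compound 1 and compound 2 there is no separation: no change at the digits printed from compound 1 to compound 2 (within the scatter).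

Compound 4, `CNC(=O)c1ccc(N/N=C2\CCC(C)n3c2ncc(C(=O)O)c3=O)cc1`, differs from compound 3 in one place: methylcarbamoyl in place of butyl on an aromatic carbon. The two steps that bear on this change are those leading to compound 3, in which butyl entered in place of bromo or of methoxy and the number rose by a modest amount each time. The change to compound 4 removes the butyl again, so the pattern within these three compounds points to the number falling back toward the level of compound 1 and compound 2. Methylcarbamoyl itself has not been measured in this series, which leaves the size of the return uncertain, and the range is set wide accordingly.

On this basis compound 4 is expected to show a 5.2-fold lower number from compound 3 to compound 4 (0.72 log units; beyond the scatter). The estimate for compound 4 in this assay is 1.5 umol/kg, with a range from 0.4 umol/kg to 6 umol/kg.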

Compound 4, dose for 50% inhibition: 9.6 umol/kg
Compound 4: middle estimate off by 6.4-fold (0.81 log units), on the low side, and the stated range ends below it.
By their numbers in this assay, from the lowest: compounds 1 and 2 (each within the scatter of the next); then compounds 3 and 4 (each within the scatter of the next).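

In this assay, among these compounds, methylcarbamoyl and butyl do not separate at this aromatic carbon, with a 1.2-fold higher number from compound 3 to compound 4 (0.09 log units; within the scatter) and so the higher number seen with butyl in the earlier compounds now proves not to be confined to an all-carbon chain. Methylcarbamoyl brings 1 hydrogen-bond donor and 1 hydrogen-bond acceptor where butyl has neither, and both groups carry 4 heavy atoms, yet the swap of methoxy for methylcarbamoyl gives a 12-fold higher number from compound 2 to compound 4 (1.08 log units; beyond the scatter) and the swap of bromo for methylcarbamoyl gives a 12-fold higher number from compound 1 to compound 4 (1.08 log units; beyond the scatter) as large steps that leave the four compounds in two groups, one holding compounds 1 and 2 and the other compounds 3 and 4. Nothing available explains why butyl and methylcarbamoyl fall together here.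

The compounds shown leave open which feature sets a group's place in these two levels, since the two groups at the higher level share their heavy-atom count but differ in their atoms and in their donors and acceptors. From the compounds shown here alone, whether an amine, a carboxylic acid, an ethyl group or a longer chain at this carbon would join compounds 1 and 2 or compounds 3 and 4 also remains open.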